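This account rests on a few compounds, and the source may have more. Where it says the series, first, only, none or still open, it means among the compounds named here.

Series notes. Compound 1 `CN(C)C(=O)c1cc2cnc(Nc3ccc(NC(=O)C4(C(=O)Nc5cccc(Cl)c5)CC4)cc3)nc2n1C1CCCC1` is the reference point of the set; in a functional assay on A549 cells (Homo sapiens) for inhibition, read by CCK-8 assay, with a stated time of 72 h, tested at 10 uM (on this read-out lower numbers stand for less inhibition of growth and higher numbers for more inhibition of growth at the one concentration tested), compound 1 gives 90.7%, the higher of the two numbers recorded so far. The only other measured entry, compound 2 `Nc1ccc(NC(=O)C2(C(=O)Nc3ccc(F)cc3)CC2)cc1F`, lacks the shared core of compound 1, and in this assay compound 2 gives 14.6%, a figure far below that of compound 1 and well beyond the usual scatter. Among the measured compounds shown here, no step between measured compounds that differ in a single place is available, so the effect of an isolated change on this read-out is unknown. Compound 3 `CN(C)C(=O)c1cc2cnc(Nc3ccc(NC(=O)C4(C(=O)Nc5ccc(O)cc5)CC4)cc3)nc2n1C1CCCC1` keeps the whole of compound 1 apart from one alteration: 4-hydroxyphenyl in place of 3-chlorophenyl on an amide-type nitrogen. With nothing measured for a change of this kind, the expectation is a modest loss or none beyond the scatter, estimated as a number 10.7 percentage points lower from compound 1 to compound 3 (beyond the scatter). On that basis compound 3 is expected to give about 80% in this assay, with a plausible range from 55% to 95%.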

Compound 3, percent growth inhibition at one concentration: 94.4%
Estimate against measurement, compound 3: 14.4 percentage points below, within the range that was stated.
By their numbers in this assay, from the lowest: compound 2; then compounds 1 and 3 (each within the scatter of the next).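

In this assay, among the compounds shown here, 4-hydroxyphenyl in place of 3-chlorophenyl on an amide-type nitrogen gives a number 3.7 percentage points higher from compound 1 to compound 3 (within the scatter) and is the first single-place step available. At this position, a ring with a hydrogen-bond donor and acceptor can therefore replace one with neither, and oxygen can replace chlorine, without a change in growth inhibition beyond the scatter at the one concentration tested. Nothing at hand accounts for this result.

The step changes both the substituent and its place on the ring, so the contribution of each remains unresolved. Also open, from the compounds shown here alone, is whether the same holds for other groups on this nitrogen, such as 4-aminophenyl, 4-carboxyphenyl or unsubstituted phenyl.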